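The source may report more compounds than this note shows. Statements on the series, on what has been measured and on what is new or still open speak of the compounds shown alone.

In a functional assay on Jurkat cells (Homo sapiens) for cytotoxicity, read by luminescence and CellTiter-Glo, with a stated time of 3 days (a higher number here means a weaker inhibitor, a lower number a stronger inhibitor), compound 1 (`O=C(Nc1cc(C(F)(F)F)cc(C(F)(F)F)c1)c1cc(Cl)c(F)cc1O`) gives 730 nM and compound 2 (`N#Cc1cc(Cl)ccc1NC(=O)c1ccc2cccnc2c1O`) gives 170 nM as the lower of the two numbers, with the gap between them beyond the scatter. Compound 3 (`O=C(Nc1ccc(Cl)cc1Cl)c1ccc2cccnc2c1O`), not yet measured, keeps the shared core of compound 2 and carries chloro in place of cyano on an aromatic carbon, ortho to a large group and meta to a chloro group (chloro in place of cyano on an aromatic carbon). Among the compounds with values here, no step between measured compounds isolates this change, so the expectation rests only on compound 2 at 170 nM and on the change itself. In this assay a small step toward a higher number is expected, most likely within the scatter. The expected change is a 1.5-fold higher number from compound 2 to compound 3 (0.18 log units; within the scatter) on this estimate. Compound 3 is expected at 260 nM (estimated range 90 nM to 750 nM).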

Compound 3, half-maximal inhibitory concentration: 430 nM
Compound 3: the middle estimate sits 1.7-fold (0.22 log units) below what was measured; the measured number falls inside the stated range.
By their numbers in this assay, from the lowest: compound 2; then compounds 3 and 1 (each within the scatter of the next).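

Chloro in place of cyano on this aromatic carbon, ortho to a large group and meta to a chloro group, is the only single-place change in the series so far. In this assay it gives a 2.5-fold higher number from compound 2 to compound 3 (0.40 log units; beyond the scatter), a modest step that shows this position responds to a change of group, with cyano giving the lower number of this pair. No measurement on hand accounts for the step.

The compounds shown leave open how other groups at this position, such as methoxy, an amine or a carboxylic acid, would read in this assay. Also open, as far as these compounds go, is whether the same exchange would give a step of similar size if the chloro group on the same ring were replaced.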